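Swapping a saturated amine for an aromatic azole at the chain carbon

The source may report more compounds than this note shows. Statements on the series, on what has been measured and on what is new or still open speak of the compounds shown alone.

Compound 1 `CCC(C)n1ncn(-c2ccc(N3CCN(c4ccc(OC[C@@H]5CO[C@@](CN6CCNCC6)(c6ccc(Cl)cc6Cl)O5)cc4)CC3)cc2)c1=O` was tested in a functional assay on HUVEC cells (Homo sapiens), read by scintillation counting and thymidine incorporation, with a stated time of 24 h (on this read-out lower numbers stand for stronger inhibition and higher numbers for weaker inhibition), where compound 1 gives 608 nM. Going by the values given here, it stands alongside compound 2 `CCC(C)n1ncn(-c2ccc(N3CCN(c4ccc(OC[C@@H]5CO[C@@](Cn6cc(C(F)(F)F)nc6C)(c6ccc(Cl)cc6Cl)O5)cc4)CC3)cc2)c1=O`, the only other measured compound; in this assay compound 2 gives 441 nM, and the gap between them is within the scatter. Compound 3 `CCC(C)n1ncn(-c2ccc(N3CCN(c4ccc(OC[C@@H]5CO[C@@](Cn6ncnn6)(c6ccc(Cl)cc6Cl)O5)cc4)CC3)cc2)c1=O` differs from compound 1 by 2H-tetrazol-2-yl in place of piperazin-1-yl on a saturated chain carbon bound to a saturated ring carbon. Among the compounds with values here, the one measured step that bears on this, a 1.4-fold lower number from compound 1 to compound 2 (0.14 log units; within the scatter), also replaced that saturated ring with an aromatic five-membered ring and stayed within the scatter. The expected step of a 1.2-fold lower number from compound 1 to compound 3 (0.08 log units; within the scatter) is therefore none beyond the scatter, and compound 3 is estimated at 500 nM, in a range from 200 nM to 1500 nM.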

Compound 3, half-maximal inhibitory concentration: 124 nM
Compound 3: the middle estimate sits 4.0-fold (0.61 log units) above what was measured; the whole stated range lies above it.
By their numbers in this assay, from the lowest: compound 3; then compounds 2 and 1 (each within the scatter of the next).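

In this assay, 2H-tetrazol-2-yl in place of piperazin-1-yl gives a 4.9-fold lower number from compound 1 to compound 3 (0.69 log units; beyond the scatter) and shows that this chain carbon responds to the group it carries. Being an aromatic five-membered ring is not enough on its own: 2H-tetrazol-2-yl in place of 2-methyl-4-(trifluoromethyl)-1H-imidazol-1-yl gives a 3.6-fold lower number from compound 2 to compound 3 (0.55 log units; beyond the scatter) in the same assay. No measurement shown here explains either step.

From the compounds shown here alone, whether 1H-tetrazol-1-yl or 1H-1,2,4-triazol-1-yl on the same carbon would match compound 3 remains open. Three compounds in one assay also cannot establish a wider trend.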